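The source may report more compounds than this note shows. Statements on the series, on what has been measured and on what is new or still open speak of the compounds shown alone.

Two compounds of the series have so far been run in an ADME assay on microsomes from liver (Mus musculus) for metabolic stability, read by LC-MS, using NADPH, with a stated time of 45 min, tested at 0.5 uM; a lower number here means slower removal, a higher number faster removal of the compound. Compound 1, `CS(=O)(=O)C1CCN(C(=O)CCSc2nc3cc(Cl)ccc3o2)CC1`, gives 2.6 mL/min/g in this assay. Compound 2, `O=C(CCSc1nc2cc(Cl)ccc2o1)N1CCC1`, gives 17.9 mL/min/g in this assay, the higher of the two numbers; the gap between compound 2 and compound 1 lies beyond the usual scatter, so compound 2 is removed faster than compound 1 in this preparation. Compound 3, `O=C(CCSc1nc2cc(Cl)ccc2o1)N1CCCCC1`, has not yet been measured. It differs from compound 2 in one place: piperidin-1-yl in place of azetidin-1-yl on a carbonyl carbon. For the measured compounds named here, no measured pair in the set carries this change, so its effect on clearance is not known from the data at hand. The expected step from compound 2 to compound 3 in this assay is a 1.2-fold higher number from compound 2 to compound 3 (0.09 log units; within the scatter), a small rise that may still fall within the scatter. Compound 3 is expected to give about 22 mL/min/g in this assay, with a likely range from 9 mL/min/g to 50 mL/min/g.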

Compound 3, intrinsic clearance in a liver preparation (reported as CLH), per the amount of preparation that the assay uses: 128 mL/min/g
Compound 3: middle estimate off by 5.8-fold (0.76 log units), on the low side; measured number above the stated range.
By their numbers in this assay, from the lowest: compound 1; then compound 2; then compound 3.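

In this assay the group on the carbonyl carbon proves to be a sensitive place, since piperidin-1-yl in place of azetidin-1-yl gives (a 7.2-fold higher number from compound 2 to compound 3 (0.85 log units; beyond the scatter)) with the rest of the molecule unchanged. The saturated ring carbon of the piperidine weighs more still: hydrogen in place of methylsulfonyl there gives (a 49-fold higher number from compound 1 to compound 3 (1.69 log units; beyond the scatter)), so the clearance of the unsubstituted piperidin-1-yl amide depends strongly on that one substituent. Nothing at hand gives a reason for either step.

Two ring sizes on the carbonyl carbon cannot show whether the number climbs steadily with size, and pyrrolidin-1-yl, the five-membered ring, would test this. From the compounds shown here alone, it also remains open whether the low number of compound 1 is particular to methylsulfonyl, or whether a hydroxyl or a carboxylic acid on the same ring carbon would serve as well.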